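Working notes: methoxy to hydroxy, compound 2 to compound 3

The source may report more compounds than this note shows. Statements on the series, on what has been measured and on what is new or still open speak of the compounds shown alone.

Measured so far:
compound 1 `O=C(Nc1cccc(-n2cc(-c3ccncc3)c(-c3ccc(Cl)c(O)c3)n2)c1)Nc1ccc(Cl)c(Cl)c1`, 993 nM
compound 2 `COc1cc(-c2nn(-c3cccc(NC(=O)Nc4ccc(Cl)c(C(F)(F)F)c4)c3)cc2-c2ccncc2)ccc1Cl`, 1110 nM

In a functional assay on NCI-H460 cells (Homo sapiens) for inhibition, read by sulforhodamine B assay, with a stated time of 48 h (a lower number here means a stronger inhibitor of growth, a higher number a weaker inhibitor of growth), compound 1 gives 993 nM and compound 2 gives 1110 nM; the two numbers lie within the usual scatter of each other, so compound 2 does not stand apart from compound 1. Compound 3 `O=C(Nc1cccc(-n2cc(-c3ccncc3)c(-c3ccc(Cl)c(O)c3)n2)c1)Nc1ccc(Cl)c(C(F)(F)F)c1` is not yet measured. Relative to compound 2 it carries hydrogen in place of methyl on an oxygen on an aromatic ring. Going by the values given here, no measured pair isolates this change, so no shift beyond the scatter is expected in either direction; the step of a 1.2-fold lower number from compound 2 to compound 3 (0.07 log units; within the scatter) is expected to stay within the scatter. Compound 3 is estimated at 950 nM, with a range from 400 nM to 2300 nM.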

Compound 3, concentration for 50% growth inhibition: 1010 nM
Compound 3: middle estimate off by 1.1-fold (0.03 log units), on the low side, and the stated range covers the measured number.
By their numbers in this assay, from the lowest: compounds 1, 3 and 2 (each within the scatter of the next).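

In this assay the first pair isolating methoxy to hydroxy gives a 1.1-fold lower number from compound 2 to compound 3 (0.04 log units; within the scatter) and so does not separate the two groups at this oxygen on the 4-chloro-3-hydroxyphenyl ring. With that hydroxy held constant, trifluoromethyl in place of chloro gives a 1.0-fold higher number from compound 1 to compound 3 (0.01 log units; within the scatter) and likewise separates nothing. No measurement offers an explanation for either result.

As far as these compounds go, whether an amine or a longer chain such as ethoxy at this position would also stay within the scatter remains open. A single pair for each change also leaves open whether either result holds elsewhere in the series.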